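The source may report more compounds than this note shows. Statements on the series, on what has been measured and on what is new or still open speak of the compounds shown alone.

Compound 2 `COc1ccccc1C(=O)Nc1cccc(NC(=O)C2CCCCC2)c1` is one of two related amides built on the same core, differing from compound 1 `COc1ccccc1C(=O)Nc1cccc(NC(=O)c2ccc(Cl)cc2)c1` only in the group on the carbonyl carbon. In an in vitro functional assay on HEK293-A cells for antagonist activity at metabotropic glutamate receptor 5 (Rattus norvegicus), read by calcium flux (on this read-out higher numbers stand for weaker inhibition and lower numbers for stronger inhibition), compound 2 gives no number but a limit, > 30000 nM. Compound 1 in this assay likewise gives only a limit, > 30000 nM. Both values sit at the limit of > 30000 nM in this assay, at which 2 of the 2 values shown sit, so the step that the two limits leave unreadable from compound 1 to compound 2 cannot be read, and nothing about its size or direction is known.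

Compound 3 `COc1ccccc1C(=O)Nc1cccc(NC(=O)C(C)C)c1` continues the same series with a smaller group on that carbon: isopropyl in place of cyclohexyl on a carbonyl carbon. No measured step bears on this change, since the only step in hand is itself unreadable, and compound 2 stands at the limit of this assay with no room shown for a weaker value to be resolved. The expectation for compound 3 is therefore that it, too, will be reported only as a limit, and any real step that the limit leaves unreadable from compound 2 to compound 3 is expected to remain hidden. If a number were returned, compound 3 would be expected near 40000 nM, within a range from 10000 nM to 150000 nM.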

Compound 3, half-maximal inhibitory concentration: > 30000 nM
Compound 3 gave a limit, no number (the forecaster's own chance of this, stated with the estimate: 85%); the middle value does not contradict the limit.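

In this assay compound 3 also gives only a limit, so no step from compound 1 or compound 2 to compound 3 can be read, and all three compounds share that limit: the limit of > 30000 nM in this assay, at which 3 of the 3 values shown sit.

The compounds shown leave open whether any group on this carbonyl carbon gives measurable inhibition, and how 4-chlorophenyl, cyclohexyl and isopropyl rank against one another.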